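Bornyl amino esters: cytotoxicity tolerance across the amine head group

The compounds below may be only part of what the source reports. "The series", "measured", "known", "first", "only" and "open" are said of these compounds alone.

Among the compounds with values here, compound 1 `CC1(C)[C@H]2CC[C@]1(C)[C@H](OC(=O)CN1CCCC1)C2` gives 302000 nM in an ADME assay on MDCK cells (Canis lupus familiaris) for cytotoxicity, read by MTT assay, with a stated time of 48 h (a higher number here means that more compound is tolerated, a lower number that less compound is tolerated), the highest of the three numbers so far. Compound 2 `CCN1CCN(CCC(=O)O[C@@H]2C[C@@H]3CC[C@@]2(C)C3(C)C)CC1` gives 105000 nM in this assay, and compound 3 `CCCCN(CCCC)CCC(=O)O[C@@H]1C[C@@H]2CC[C@@]1(C)C2(C)C` gives 41800 nM; both sit beyond the scatter below compound 1, with compound 3 furthest off. Compound 4 `CC1CCN(CC(=O)O[C@@H]2C[C@@H]3CC[C@@]2(C)C3(C)C)CC1` carries the change (4-methylpiperidin-1-yl in place of pyrrolidin-1-yl on a saturated chain carbon bound to a carbonyl carbon). Within the data shown here, no directly comparable step is measured, so the expectation rests on compound 1 at 302000 nM and on the lower numbers of compound 2 and compound 3 as the amine grows: a modest drop beyond the scatter is expected, as a 2.0-fold lower number from compound 1 to compound 4 (0.30 log units; within the scatter). Compound 4 is estimated at 150000 nM, in the range 60000 nM to 400000 nM.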

Compound 4, half-maximal cytotoxic concentration: 93900 nM
For compound 4 the middle estimate is 1.6-fold (0.20 log units) above the measured one; low and high end bracket the measured number.
By their numbers in this assay, from the lowest: compound 3; then compounds 4 and 2 (each within the scatter of the next); then compound 1.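

In this assay, the series gains its first comparison that differs in one place, on a saturated chain carbon bound to a carbonyl carbon: 4-methylpiperidin-1-yl in place of pyrrolidin-1-yl gives a 3.2-fold lower number from compound 1 to compound 4 (0.51 log units; beyond the scatter). With the rest of the structure held fixed, the amine head group alone is enough to shift this number. Nothing measured here accounts for the step.

On these data alone, whether the six-membered ring or the methyl group carries the step stays open; piperidin-1-yl without the methyl group would separate the two. As far as these compounds go, how morpholin-4-yl at this place would read also remains open.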